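The source may report more compounds than this note shows. Statements on the series, on what has been measured and on what is new or still open speak of the compounds shown alone.

Compound 1: `CC(=O)c1ccc(N/N=C2\CCC(C)n3c2ncc(C(=O)O)c3=O)cc1`, > 100 umol/kg
Compound 2: `CCCCc1ccc(N/N=C2\CCC(C)n3c2ncc(C(=O)O)c3=O)cc1`, 100 umol/kg

Within the data shown here, in a functional assay on the whole organism for inhibition, with Rattus norvegicus as the target (a higher number here means that more compound is needed for the effect, a lower number that less compound is needed), compound 2 gives 100 umol/kg, the only plain number in this set. For compound 1 the result is > 100 umol/kg, which is a limit of the assay rather than a number. The step of a number no higher from compound 1 to compound 2 (the limit leaves the size open) therefore has no readable size, because its starting point is the limit of > 100 umol/kg in this assay, at which 1 of the 2 values shown sits.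

The unmeasured compound 3 is `CNC(=O)c1ccc(N/N=C2\CCC(C)n3c2ncc(C(=O)O)c3=O)cc1`. It differs from compound 2 by methylcarbamoyl in place of butyl on an aromatic carbon. Among the measured compounds shown here, the only measured step that touches this position is a number no higher from compound 1 to compound 2 (the limit leaves the size open), and it gives no size, so there is nothing to set the direction of the new step firmly. Compound 3 is therefore expected to move only modestly, the expected step being a 1.5-fold higher number from compound 2 to compound 3 (0.18 log units; within the scatter). Compound 3 is estimated at 150 umol/kg, with a likely range from 60 umol/kg to 400 umol/kg, and a fair chance that this assay reports only a limit.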

Compound 3, dose for 50% inhibition: > 100 umol/kg
Compound 3: a limit, no number; the forecaster's own chance of this, stated with the estimate: 55%; the middle value lies beyond the limit too.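

In this assay compound 3 gives > 100 umol/kg, which is a limit of the assay and not a number. Among these compounds, putting methylcarbamoyl in place of butyl, on an aromatic carbon para to a large group, gives a number no lower from compound 2 to compound 3 (the limit leaves the size open), so methylcarbamoyl joins the acetyl of compound 1 at the limit, and butyl in compound 2 remains the only group at this position with a plain number. The sizes of the steps among these compounds cannot be read: the limit of > 100 umol/kg in this assay, at which 2 of the 3 values shown sit.

From the compounds shown here alone, how far the number can move at this position, in either direction, stays open. A longer chain such as hexyl, or an amine or a carboxylic acid on the same aromatic carbon, could show whether the plain number belongs to carbon chains in general or to butyl alone.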